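From Methyl to 3-Methoxyphenyl: Expecting Little Change

A few compounds are considered here, and "the series" means these few. Any claim that something is new, unique, unknown or untested is made for them only; others in the source may bear on it.

Among the measured compounds shown here, compound 1 `CNC(=S)N/N=C/c1cccc2ccccc12` gives 2000 nM in a functional assay on B16 cells (Mus musculus), read by spectrophotometry, with a stated time of 3 days (on this read-out lower numbers stand for stronger inhibition and higher numbers for weaker inhibition), the highest of the two numbers so far. Compound 2 `S=C(N/N=C/c1cccc2ccccc12)Nc1ccc(Cl)cc1` gives 1900 nM in this assay, and the step of a 1.1-fold lower number from compound 1 to compound 2 (0.02 log units; within the scatter) came from 4-chlorophenyl in place of methyl on an amide-type nitrogen. Compound 3 `COc1cccc(NC(=S)N/N=C/c2cccc3ccccc23)c1` differs from compound 1 by 3-methoxyphenyl in place of methyl on an amide-type nitrogen. For the measured compounds named here, the only comparable step is the one from compound 1 to compound 2, which stayed within the scatter, so no movement beyond the scatter is expected here; the estimated step is a 1.1-fold lower number from compound 1 to compound 3 (0.02 log units; within the scatter). Compound 3 is therefore expected at 1900 nM, within a range from 800 nM to 4500 nM.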

Compound 3, half-maximal inhibitory concentration: 830 nM
Compound 3: middle estimate off by 2.3-fold (0.36 log units), on the high side; low and high end bracket the measured number.
By their numbers in this assay, from the lowest: compound 3; then compounds 2 and 1 (each within the scatter of the next).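

In this assay this place on the amide-type nitrogen does respond to a change of group: 3-methoxyphenyl gives a 2.4-fold lower number from compound 1 to compound 3 (0.38 log units; beyond the scatter) while 4-chlorophenyl stayed within the scatter of methyl. The choice between the two phenyl groups also counts, with a 2.3-fold lower number from compound 2 to compound 3 (0.36 log units; beyond the scatter) and so the added ring alone does not set the number. No measurement at hand explains the difference between these two groups.

Still open, from the compounds shown here alone, is whether 4-methoxyphenyl would match 3-methoxyphenyl. Also open, going by these compounds, is how a phenyl ring carrying an amine or a carboxylic acid, or a longer chain such as butyl, would read here.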